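The compounds below may be only part of what the source reports. "The series", "measured", "known", "first", "only" and "open" are said of these compounds alone.

Compound 1 `CC(C)CN(NC(=O)OCc1ccccc1)C(=O)CN(Cc1ccccc1)NC(=O)Cc1cccc(Br)c1` and compound 2 `CC(C)CN(CC(=O)NN(Cc1ccccc1)c1cnccn1)NC(=O)Cc1cccc(Br)c1` are built on different cores; the difference between the two cores is not broken down here. In a functional assay on B16 cells (Mus musculus) for inhibition (a lower number here means a stronger inhibitor, a higher number a weaker inhibitor), compound 1 gives > 80000 nM, which is a limit of the assay and not a number. Compound 2 gives 23400 nM in this assay. Compound 3 `CC(C)CN(NC(=O)OCc1ccccc1)C(=O)CN(Cc1ccccc1)/N=C/c1cccc(B(O)O)c1` is compound 1 with a group of 11 heavy atoms (7 carbon, 1 boron, 1 nitrogen, 2 oxygen; one six-membered aromatic ring of carbon only) in place of a group of 11 heavy atoms (8 carbon, 1 nitrogen, 1 oxygen, 1 bromine; one six-membered aromatic ring of carbon only), on an amine nitrogen; in this assay compound 3 gives 20400 nM. The measured step is an at least 3.9-fold lower number from compound 1 to compound 3 (0.59 log units; beyond the scatter), known only as a bound since the limit of > 80000 nM in this assay, at which 1 of the 3 values shown sits, fixes its starting point. Compound 2 and compound 3 give numbers within the scatter of each other.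

Compound 4 `CC(C)CN(CC(=O)NN(Cc1ccccc1)c1cnccn1)/N=C/c1cccc(B(O)O)c1` is compound 2 with the same change, (a group of 11 heavy atoms (7 carbon, 1 boron, 1 nitrogen, 2 oxygen; one six-membered aromatic ring of carbon only) in place of a group of 11 heavy atoms (8 carbon, 1 nitrogen, 1 oxygen, 1 bromine; one six-membered aromatic ring of carbon only), on an amine nitrogen), made on the same place, so it is the same change. The step expected here is a 3.3-fold lower number from compound 2 to compound 4 (0.52 log units; beyond the scatter), set beside the measured step of an at least 3.9-fold lower number from compound 1 to compound 3 (0.59 log units; beyond the scatter), on which the expectation rests; as that step is only a bound, the expected size is uncertain. The expected number for compound 4 in this assay is 7000 nM, estimated to lie within 1500 nM to 30000 nM.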

Compound 4, half-maximal inhibitory concentration: > 80000 nM
Compound 4 ended at the assay's limit; the forecaster's own chance of this, stated with the estimate: 5%; middle value at least 11-fold (1.05 log units) away from the limit.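

In this assay, placing the boron-bearing group on the amine nitrogen in place of the bromine-bearing group gives an at least 3.4-fold higher number from compound 2 to compound 4 (0.53 log units; beyond the scatter). Set beside the earlier step, this shows that the change does not carry over from the core of compound 1 to the core of compound 2, and the direction reverses: the same change on two cores in this assay, an at least 3.9-fold lower number (0.59 log units; beyond the scatter) from compound 1 to compound 3 and an at least 3.4-fold higher number (0.53 log units; beyond the scatter) from compound 2 to compound 4, at least 13-fold (1.12 log units) apart, beyond the scatter of two such steps

Both steps are known only as bounds, so their true sizes and the true gap between them stay unknown, and a single pair on each core does not show how the change would behave on any other core in the series: the limit of > 80000 nM in this assay, at which 2 of the 4 values shown sit.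

The leaving and entering groups differ in more than one part, and the compounds shown do not separate the effect of the boron-bearing ring from that of the link joining it to the amine nitrogen. Going by these compounds, it also remains open whether either core would respond in the same direction to a carboxylic acid on that ring in place of the boron-bearing part.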